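The source may hold more compounds than are shown below. What is called first, only, known or untested is meant among the compounds shown, and "the series" means these compounds.

In a functional assay on HL-60 cells (Homo sapiens) for inhibition, read by MTT assay, with a stated time of 48 h, tested at 10 uM (on this read-out higher numbers stand for more inhibition of growth at the one concentration tested and lower numbers for less inhibition of growth), three compounds have been read so far. Compound 1 `Cc1cc(=O)c2c(O)cc(OCc3ccccc3)c([C@H]3CCN(C)C[C@H]3O)c2o1` gives 24%, compound 2 `Cc1cc(=O)c2c(O)cc(OCc3ccc(Br)cc3)c([C@H]3CCN(C)C[C@H]3O)c2o1` gives 27%, and compound 3 `Cc1oc2c([C@H]3CCN(C)C[C@H]3O)c(O)cc(O)c2c(=O)c1C(O)c1ccc(F)c(Br)c1` gives 25%. Compound 3 thus stands within the scatter of both other compounds, and the numbers support no ranking among the three.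

The next compound, compound 4 `Cc1oc2c([C@H]3CCN(C)C[C@H]3O)c(O)cc(O)c2c(=O)c1C(O)c1cccc(Cl)c1Cl`, keeps the rest of compound 3 and alters one group: 2,3-dichlorophenyl in place of 3-bromo-4-fluorophenyl on a saturated chain carbon bound to an aromatic carbon and an oxygen on a saturated carbon. Thus 2,3-dichlorophenyl takes the place of 3-bromo-4-fluorophenyl on a saturated chain carbon bound to an aromatic carbon and an oxygen on a saturated carbon.

Within the data shown here, only one measured step offers any guidance, and it is indirect: a number 3 percentage points higher from compound 1 to compound 2 (within the scatter). That step places bromo in place of hydrogen on an aromatic carbon, but at a different place in the molecule. Among the measured compounds shown here, no measured pair exchanges one halogen-bearing phenyl group for another at the site that changes here. The available evidence therefore gives no reason to expect a shift beyond the scatter, in either direction. The expected change is small: a number 1 percentage points higher from compound 3 to compound 4 (within the scatter). Compound 4 is estimated at 26%, with an expected range from 14% to 40%.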

Compound 4, percent growth inhibition at one concentration: 12%
The estimate for compound 4 lay 14 percentage points above the measured number, outside the stated range (below it).
By their numbers in this assay, from the lowest: compound 4; then compounds 1, 3 and 2 (each within the scatter of the next).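

In this assay, the aryl group on a saturated chain carbon bound to an aromatic carbon and an oxygen on a saturated carbon proves able to move the read-out: 2,3-dichlorophenyl in place of 3-bromo-4-fluorophenyl gives a number 13 percentage points lower from compound 3 to compound 4 (beyond the scatter), whereas the earlier halogen change at another place in the molecule gave a number 3 percentage points higher from compound 1 to compound 2 (within the scatter) and stayed within the scatter. The two groups match in heavy atoms, ring type, hydrogen-bond donors and acceptors and net charge, and differ in which halogens they carry and in the places those halogens take on the ring, so an exchange confined to these features is enough to lower the number at this site. Nothing measured here tells why the number falls.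

The compounds shown do not separate the identity of the halogens from their placement on the ring, so it stays open whether the chlorine atoms or their arrangement account for the lower number. Also open, as far as these compounds go, is how this position would read with an unsubstituted phenyl, a methoxyphenyl, an aminophenyl or a cyclohexyl group on the same carbon.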